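Difluorophenyl in Place of Methoxyphenyl on the Carbonyl Carbon

The source may report more compounds than this note shows. Statements on the series, on what has been measured and on what is new or still open speak of the compounds shown alone.

Compound 1 `COc1cc(-c2cc(/C=C/C(=O)c3ccc(N)cc3)[nH]n2)cc(OC)c1OC` gives 88% in a functional assay on Hs-578T cells (Homo sapiens) for cytotoxicity, read by sulforhodamine B assay, with a stated time of 48 h, tested at 0.1 uM; on this read-out lower numbers stand for a stronger effect and higher numbers for a weaker effect at the one concentration tested. Compound 2 `COc1ccc(C(=O)/C=C/c2cc(-c3cc(OC)c(OC)c(OC)c3)n[nH]2)cc1OC` gives 99%. Compound 3 `COc1ccc(C(=O)/C=C/c2cc(-c3cc(OC)c(OC)c(OC)c3)n[nH]2)cc1` gives 100%.

Compound 3 has the highest number of the three, but its nearest neighbour lies within the scatter, as a number 1 percentage points higher from compound 2 to compound 3 (within the scatter) shows; only compound 1 sits clearly apart, with a number 12 percentage points higher from compound 1 to compound 3 (beyond the scatter) and a number 11 percentage points higher from compound 1 to compound 2 (beyond the scatter) both modest.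

Compound 4 `COc1cc(-c2cc(/C=C/C(=O)c3ccc(F)c(F)c3)[nH]n2)cc(OC)c1OC` differs from compound 3 in one place: 3,4-difluorophenyl in place of 4-methoxyphenyl on a carbonyl carbon. Among the compounds with values here, no measured step introduces fluorine. Within the data shown here, the only step at this site that keeps the amino group out, the one from compound 2 to compound 3, stayed within the scatter, so compound 4 is expected to move little, with a number 5 percentage points lower from compound 3 to compound 4 (within the scatter) in this assay. Compound 4 is therefore estimated at 95%, from 80% to 104%.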

Compound 4, a percentage reported as activity, at one concentration (the size of the read-out at that concentration, not a potency): 97%
For compound 4 the middle estimate is 2 percentage points below the measured one; the range from low to high includes it.
By their numbers in this assay, from the lowest: compounds 1, 4, 2 and 3 (each within the scatter of the next, the first and the last beyond it).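

In this assay, within the data shown here, the first fluorine-bearing group at this carbonyl carbon gives a number 3 percentage points lower from compound 3 to compound 4 (within the scatter) and a number 2 percentage points lower from compound 2 to compound 4 (within the scatter) but also a number 9 percentage points higher from compound 1 to compound 4 (within the scatter) and so does not fall on either side of the earlier split. Unlike 3,4-dimethoxyphenyl and 4-methoxyphenyl, 3,4-difluorophenyl therefore does not stand clearly apart from 4-aminophenyl at this position. Nothing available accounts for this result.

Going by these compounds, it remains open whether 4-hydroxyphenyl or 4-carboxyphenyl on this carbonyl carbon would separate from compound 1 . The compounds also leave open how a single fluorine would read here.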